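Acid-to-anilide step on a dihydrofuran carboxylic acid series

A few compounds are considered here, and "the series" means these few. Any claim that something is new, unique, unknown or untested is made for them only; others in the source may bear on it.

Of the compounds shown here, three sharing one core have numbers so far. Compound 1 `C=CC1=C(C(=O)O)C(c2ccc(F)cc2)OC1` gives 67400 nM in a functional assay on HeLa cells (Homo sapiens) for cytotoxicity, read by MTT assay, with a stated time of 24 h; on this read-out higher numbers stand for weaker inhibition and lower numbers for stronger inhibition. Compound 2 `C=CC1=C(C(=O)O)C(c2ccc(OC)cc2)OC1` gives 44300 nM in this assay, and compound 3 `C=CC1=C(C(=O)O)C(c2ccc(OC)c(OC)c2)OC1` gives 18000 nM in this assay. Among these three numbers compound 2 stands second highest: its nearest neighbour is compound 1, with a 1.5-fold lower number from compound 1 to compound 2 (0.18 log units; within the scatter), and its furthest is compound 3, with a 2.5-fold lower number from compound 2 to compound 3 (0.39 log units; beyond the scatter).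

The next compound is compound 4 `C=CC1=C(C(=O)Nc2ccc(C)cc2)C(c2ccc(OC)cc2)OC1`. Its change from compound 2 is (4-methylphenyl)amino in place of hydroxy on a carbonyl carbon. Among the measured compounds shown here, both measured steps concern substituents on the aromatic ring attached to the core; neither touches the carbonyl carbon, so no measured step bears directly on this change. The two ring steps were small, one within the scatter and one modest. There is no basis in the numbers for predicting a large move in this assay in either direction for this change, and the working expectation is a step no larger than the scatter, if anything towards a lower number.

Compound 4 is therefore estimated at 25000 nM in this assay, with a range from 8000 nM to 80000 nM. This estimate means an expected step of a 1.8-fold lower number from compound 2 to compound 4 (0.25 log units; within the scatter).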

Compound 4, half-maximal inhibitory concentration: > 100000 nM
Compound 4 ended at the assay's limit (the forecaster's own chance of this, stated with the estimate: 15%); at least 4.0-fold (0.60 log units) between middle value and limit.
By their numbers in this assay, from the lowest: compound 3; then compounds 2 and 1 (each within the scatter of the next). At a limit, above all of these: compound 4.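

Among the compounds shown here, replacing hydroxy with (4-methylphenyl)amino on the carbonyl carbon gives an at least 2.2-fold higher number from compound 2 to compound 4 (0.35 log units; beyond the scatter), the first measured step at this position and the first that goes towards a higher number. Compound 4 reads > 100000 nM in this assay, which is a limit of the assay and not a number. The ring steps moved the read-out only towards lower numbers, whereas this change on the carbonyl carbon moves it the other way, and its size is bounded from one side only: the limit of > 100000 nM in this assay, at which 1 of the 4 values shown sits.

The compounds shown leave open whether the higher number goes with the amide nitrogen or with the added aromatic ring, and how a plain amino group, a methoxy group or a longer alkylamino chain on this carbonyl carbon would read. Also open, going by these compounds, is whether the same (4-methylphenyl)amino change would read the same way on the fluoro-substituted ring of compound 1 or the dimethoxy-substituted ring of compound 3.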